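Taking the Acetyl Group off Compound 2

The source may hold more compounds than are shown below. What is called first, only, known or untested is meant among the compounds shown, and "the series" means these compounds.

Among the compounds with values here, in an ADME assay on THP-1 cells (Homo sapiens) for cytotoxicity, read by flow cytometry and propidium iodide staining, with a stated time of 72 h (a lower number here means a stronger inhibitor, a higher number a weaker inhibitor), compound 2 (`COc1cccc(-c2oc3ccc(NC(C)=O)cc3c(=O)c2OC)c1`) gives 5000 nM and this is the only actual number so far. Compound 1 (`COc1cccc(-c2cc(=O)c3cc(N)ccc3o2)c1`) stands at > 125000 nM which is a limit of the assay and not a number. The position of compound 2 therefore cannot yet be judged against a second measured value.

Compound 3 (`COc1cccc(-c2oc3ccc(N)cc3c(=O)c2OC)c1`) comes from compound 2 through a single change, hydrogen in place of acetyl on a nitrogen on an aromatic ring so that acetamido becomes amino. Within the data shown here, no measured step between two compounds is available to size this change in this assay and the expectation has only one firm starting point, compound 2 at 5000 nM in that test. A modest move toward weaker inhibition is expected, with considerable uncertainty about both its size and its direction. The estimated change is a 2.4-fold higher number from compound 2 to compound 3 (0.38 log units; beyond the scatter) and it would lie close to the usual scatter. Compound 3 is expected to read 12000 nM with an estimated range from 2500 nM to 60000 nM once it is measured.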

Compound 3, half-maximal inhibitory concentration: 37000 nM
Compound 3: the middle estimate sits 3.1-fold (0.49 log units) below what was measured, and the stated range covers the measured number.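

In this assay, the acetyl group on a nitrogen on an aromatic ring now has a measured size: hydrogen in its place gives a 7.4-fold higher number from compound 2 to compound 3 (0.87 log units; beyond the scatter), which makes the acetamido compound the stronger inhibitor of this pair. Compounds 1 and 2 differ in more than one place and could not show this, while compound 3 now links to each of them through a single change, and methoxy in place of hydrogen on an aromatic carbon gives an at least 3.3-fold lower number from compound 1 to compound 3 (0.52 log units; beyond the scatter). Compound 1 stands at a limit of the assay and not at a number, so this second step is a bound and its full size remains unknown: the limit of > 125000 nM in this assay, at which 1 of the 3 values shown sits.

Going by these compounds, whether acetyl on the nitrogen of compound 1 would lower its number, as it does between compound 3 and compound 2, remains open, and with the limit in place the two changes cannot be set against each other in size. On these data alone, it is also open whether a longer acyl chain such as propionyl, a methanesulfonyl group or a single methyl on that nitrogen would read closer to compound 2 or to compound 3.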